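The compounds below may be only part of what the source reports. "The series", "measured", "known", "first", "only" and "open" are said of these compounds alone.

Compounds measured so far:
- Compound 1 `Cc1ccc(-c2cc(C(=O)N3CCC4(CC3)CC(=O)c3nn(C(C)(C)C)cc3O4)c3ccccc3n2)cc1`: > 10000 nM (a limit of the assay)
- Compound 2 `CC(C)(C)n1cc2c(n1)C(=O)CC1(CCN(C(=O)c3cc(N4CCNCC4)nc4ccccc34)CC1)O2`: 4200 nM

The test here is a functional assay on MDA-MB-231 cells (Homo sapiens) for inhibition, read by MTT assay, with a stated time of 72 h; a lower number here means a stronger inhibitor, a higher number a weaker inhibitor. Within the data shown here, in it, compound 2 gives 4200 nM, the only exact number available so far. Compound 1 gives > 10000 nM, which is a limit of the assay and not a number.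

The next compound is compound 3 `CC(C)Oc1cc(C(=O)N2CCC3(CC2)CC(=O)c2nn(C(C)(C)C)cc2O3)c2ccccc2n1`, which shares its core with compound 2. It carries isopropoxy in place of piperazin-1-yl on an aromatic carbon, next to the ring nitrogen: isopropoxy in place of piperazin-1-yl on an aromatic carbon.

Among the measured compounds shown here, only one measured step bears on this change, and it involves the same place on the core. There, piperazin-1-yl took the place of 4-methylphenyl, giving an at least 2.3-fold lower number from compound 1 to compound 2 (0.37 log units; beyond the scatter). On these data alone, since compound 1 has only a limit, the true size of that step is unknown.

Given an at least 2.3-fold lower number from compound 1 to compound 2 (0.37 log units; beyond the scatter), the loss of piperazin-1-yl in compound 3 is expected to move the number upward by a modest amount. However, no measured compound yet carries isopropoxy, so this expectation is loose. The estimated change is a 2.1-fold higher number from compound 2 to compound 3 (0.33 log units; beyond the scatter). For compound 3 the estimate is 9000 nM, with an expected range of 4000 nM to 20000 nM.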

Compound 3, half-maximal inhibitory concentration: > 10000 nM
Compound 3 gave a limit, no number; the forecaster's own chance of this, stated with the estimate: 45%; middle value at least 1.1-fold (0.04 log units) away from the limit.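

In this assay, among these compounds, compound 2 is still the only compound with an exact value, and two different groups at this position, 4-methylphenyl and isopropoxy, now fail to match it. Replacing piperazin-1-yl with isopropoxy gives an at least 2.3-fold higher number from compound 2 to compound 3 (0.37 log units; beyond the scatter), so the earlier step no longer stands alone: the lower number has now been lost with a second, quite different replacement, one that has no ring and no hydrogen-bond donor. The step from compound 1 to compound 3 cannot be read, so 4-methylphenyl and isopropoxy cannot be ranked against each other, and the true size of both steps involving compound 2 stays hidden behind the same ceiling: the limit of > 10000 nM in this assay, at which 2 of the 3 values shown sit.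

The compounds shown leave open which part of piperazin-1-yl goes with the lower number, the ring or its second nitrogen, and a morpholin-4-yl group or an open-chain amine at this place would help separate the two. On these data alone, it is also open whether any group here can bring the number well under that of compound 2, which gives 4200 nM.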